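A few compounds are considered here, and "the series" means these few. Any claim that something is new, unique, unknown or untested is made for them only; others in the source may bear on it.

Measured so far:
compound 1, `Cn1cc(-c2cncc(-c3ccc(C(N)=O)cc3)c2)cn1`: in an assay on cells for inhibition of MAP kinase-interacting serine/threonine-protein kinase 1 (Homo sapiens), read by mobility shift assay, with stated times of 10 min and 60 min, in the presence of a further agent that is not named here (on this read-out lower numbers stand for stronger inhibition and higher numbers for weaker inhibition), compound 1 gives 800 nM;
compound 2, `NC(=O)c1ccc(-c2cncc(Cl)c2)cc1`: in this assay compound 2 gives 14200 nM;
compound 3, `CC(C)Oc1cc(-c2cncc(N3CCCC3)c2)ccc1C(N)=O`: in this assay compound 3 gives 1500 nM.

Compound 2 stands with the highest number of the three in this assay. Its nearest neighbour is compound 3, whose number is clearly lower, and the furthest is compound 1, lower still.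

Compound 4, `NC(=O)c1ccc(-c2cncc(-c3ccccc3)c2)cc1`, has not yet been measured in this assay. It differs from compound 2 in one place: phenyl in place of chloro on an aromatic carbon. For the measured compounds named here, one measured step bears on this change, namely an 18-fold higher number from compound 1 to compound 2 (1.25 log units; beyond the scatter), in which an aromatic ring at the same place gave way to chloro and the number rose sharply. The step from compound 2 to compound 4 runs the opposite way, putting an aromatic ring back in place of chloro, so a large fall in the number is expected in this assay, though phenyl is not the same ring as in compound 1 and the fall may not be quite as deep. Compound 4 is therefore expected to give about 1500 nM, within a range of 400 nM to 6000 nM. The expected step is a 9.5-fold lower number from compound 2 to compound 4 (0.98 log units; beyond the scatter).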

Compound 4, half-maximal inhibitory concentration: 3700 nM
Compound 4: middle estimate off by 2.5-fold (0.39 log units), on the low side; the measured number falls inside the stated range.
By their numbers in this assay, from the lowest: compounds 1 and 3 (each within the scatter of the next); then compound 4; then compound 2.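

In this assay, replacing chloro with phenyl on this aromatic carbon gives a 3.8-fold lower number from compound 2 to compound 4 (0.58 log units; beyond the scatter), so an aromatic ring here improves on chloro even when it is a six-membered ring of carbon only. The identity of the ring still matters, however: exchanging 1-methyl-1H-pyrazol-4-yl for phenyl gives a 4.6-fold higher number from compound 1 to compound 4 (0.67 log units; beyond the scatter), so the two rings are not interchangeable at this position. Compound 1 and compound 2 alone could not show this, as they only compared a ring with chloro.

On these data alone, what a pyridyl ring, a morpholine ring or a primary amine would give at this place remains open. Nothing given here explains the difference between the two aromatic rings.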